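Chain extension on the fluorinated analogue

A few compounds are considered here, and "the series" means these few. Any claim that something is new, unique, unknown or untested is made for them only; others in the source may bear on it.

Among the compounds with values here, compound 2 `CC/C=C\C(=O)Nc1cc(Nc2nc(C)cc(-c3cn(C)c4ccc(F)cc34)n2)c(OC)cc1N(C)CCN(C)C` gives 9150 nM in a functional assay on A549 cells (Homo sapiens) for antiproliferative activity, read by MTT assay, with a stated time of 72 h (on this read-out lower numbers stand for stronger inhibition and higher numbers for weaker inhibition), the higher of the two numbers known here. Compound 1 `CCC/C=C\C(=O)Nc1cc(Nc2nc(C)cc(-c3cn(C)c4ccccc34)n2)c(OC)cc1N(C)CCN(C)C` gives 329 nM in this assay, a gap beyond the usual scatter; since these two compounds differ in more than one place, the gap cannot be assigned to any single change. Compound 3 `CCC/C=C\C(=O)Nc1cc(Nc2nc(C)cc(-c3cn(C)c4ccc(F)cc34)n2)c(OC)cc1N(C)CCN(C)C` differs from compound 2 by methyl in place of hydrogen on a saturated chain carbon, two bonds along the chain from a double-bonded chain carbon. Within the data shown here, no measured pair isolates this change. Compound 3 is expected to give about 2500 nM (range 500 nM to 12000 nM), an estimated downward step a 3.7-fold lower number from compound 2 to compound 3 (0.56 log units; beyond the scatter) that is modest and uncertain, because compound 1 with 329 nM sits far lower.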

Compound 3, half-maximal inhibitory concentration: 13300 nM
Compound 3: middle estimate off by 5.3-fold (0.73 log units), on the low side; measured number outside the range, above it.
By their numbers in this assay, from the lowest: compound 1; then compounds 2 and 3 (each within the scatter of the next).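

In this assay, going from but-1-en-1-yl to pent-1-en-1-yl on the fluorinated compounds gives a 1.5-fold higher number from compound 2 to compound 3 (0.16 log units; within the scatter) and so leaves the number at this position within the usual scatter. With the pent-1-en-1-yl chain held constant, fluoro in place of hydrogen on an aromatic carbon gives the much larger a 40-fold higher number from compound 1 to compound 3 (1.61 log units; beyond the scatter) and, among these compounds, is the only isolated change with a step beyond the scatter. No supporting data explain either step.

As far as these compounds go, whether a longer chain such as hex-1-en-1-yl would stay within the scatter remains open. Also open, from the compounds shown here alone, is whether chloro or methoxy on that aromatic carbon would give a comparable step.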